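Working notes: chloro for hydrogen on the shared core

The source may hold more compounds than are shown below. What is called first, only, known or untested is meant among the compounds shown, and "the series" means these compounds.

Measured so far:
compound 1 `ClCc1cccc(Cn2cnc3ncnc(Cl)c32)c1`: > 100000 nM
compound 2 `ClCc1ccccc1Cn1cnc2ncnc(Cl)c21`: 83200 nM
compound 3 `ClCc1cccc(Cn2cnc3nc(Cl)nc(Cl)c32)c1`: 5240 nM

In a functional assay on K562 cells (Homo sapiens) for cytotoxicity, read by sulforhodamine B assay, with a stated time of 48 h (a lower number here means that less compound is tolerated, a higher number that more compound is tolerated), compound 1 gives only a limit, > 100000 nM, and no number. Compound 3 carries the change chloro in place of hydrogen on an aromatic carbon relative to compound 1, and this gives an at least 19-fold lower number from compound 1 to compound 3 (1.28 log units; beyond the scatter); the limit of > 100000 nM in this assay, at which 1 of the 3 values shown sits, means only the lower bound of that step is known. Compound 2 shares its atoms with compound 1, joined differently; the difference between the two cores is not broken down here. In this assay compound 2 gives 83200 nM, the highest number among the measured compounds.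

Compound 4 `ClCc1ccccc1Cn1cnc2nc(Cl)nc(Cl)c21` is not yet measured. It differs from compound 2 by chloro in place of hydrogen on an aromatic carbon, the same change as from compound 1 to compound 3, since both place descriptions agree word for word. The step of a 19-fold lower number from compound 2 to compound 4 (1.28 log units; beyond the scatter) in this assay is expected to be of similar size, resting on the measured step of an at least 19-fold lower number from compound 1 to compound 3 (1.28 log units; beyond the scatter). Compound 4 is therefore estimated at 4400 nM, expected to fall between 1500 nM and 15000 nM.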

Compound 4, concentration lethal to 50% of the cells: > 100000 nM
Compound 4 gave a limit, no number; the forecaster's own chance of this, stated with the estimate: 5%; middle value at least 22-fold (1.35 log units) away from the limit.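

In this assay compound 4 gives only a limit, > 100000 nM. On the core of compound 2, chloro in place of hydrogen on an aromatic carbon gives an at least 1.2-fold higher number from compound 2 to compound 4 (0.07 log units; that floor lies within the scatter), so the drop seen on the core of compound 1 does not carry over, and the two steps do not match: the same change on two cores in this assay, an at least 19-fold lower number (1.28 log units; beyond the scatter) from compound 1 to compound 3 and an at least 1.2-fold higher number (0.07 log units; that floor lies within the scatter) from compound 2 to compound 4, at least 22-fold (1.36 log units) apart, beyond the scatter of two such steps. Both steps are known only as floors, so their true sizes stay unknown, and this single pair of cores gives neither a rule for the series nor a reason for the difference: the limit of > 100000 nM in this assay, at which 2 of the 4 values shown sit.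

The compounds shown leave open whether another group on that same aromatic carbon, such as an amine or a methoxy group, would also act differently on the two cores. They also leave open whether the gap between the cores persists when the chloromethyl group is replaced by a hydroxymethyl group.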